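This account rests on a few compounds, and the source may have more. Where it says the series, first, only, none or still open, it means among the compounds named here.

Three compounds have so far been measured in a functional assay on HCT-116 cells (Homo sapiens) for antiproliferative activity, read by MTT assay, with a stated time of 48 h; a lower number here means a stronger inhibitor, a higher number a weaker inhibitor:

Compound 1 `COc1ncc(-c2ccc3nc(N)nn3c2)cc1NS(=O)(=O)c1ccc(Cl)cc1` gives 2500 nM.
Compound 2 `COc1ncc(-c2ccc3nc(N)nn3c2)cc1NS(=O)(=O)c1ccc(C)cc1` gives 3400 nM.
Compound 3 `COc1ncc(-c2ccn3nc(NC(C)=O)nc3c2)cc1NS(=O)(=O)c1ccc(Cl)cc1` gives 1330 nM.

Compound 1 and compound 2 share one core and differ only by methyl in place of chloro on an aromatic carbon; this gives a 1.4-fold higher number from compound 1 to compound 2 (0.13 log units; within the scatter). Compound 3 is built on a different core, and how its core differs from that of compound 1 is not broken down here. Compound 4 `COc1ncc(-c2ccn3nc(NC(C)=O)nc3c2)cc1NS(=O)(=O)c1ccc(C)cc1` has not yet been measured. It arises from compound 3 by methyl in place of chloro on an aromatic carbon, the same change that leads from compound 1 to compound 2, made at the same kind of place on the ring that carries the sulfonyl group. Going by the values given here, only one earlier example of this change is available, so the expectation rests on it alone: because a 1.4-fold higher number from compound 1 to compound 2 (0.13 log units; within the scatter) stayed within the scatter, the same change is expected to give a 1.4-fold higher number from compound 3 to compound 4 (0.15 log units; within the scatter). The value of compound 4 in this assay is estimated at 1900 nM, with a likely range from 1000 nM to 3600 nM.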

Compound 4, half-maximal inhibitory concentration: 1380 nM
Compound 4: middle estimate off by 1.4-fold (0.14 log units), on the high side; the measured number falls inside the stated range.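

Replacing 4-chlorophenyl with 4-methylphenyl on the second core gives a 1.0-fold higher number from compound 3 to compound 4 (0.02 log units; within the scatter) in this assay. Set beside the earlier example, this step shows that the change behaves alike on the two cores, as far as this assay can tell: the same change on two cores in this assay, a 1.4-fold higher number (0.13 log units; within the scatter) from compound 1 to compound 2 and a 1.0-fold higher number (0.02 log units; within the scatter) from compound 3 to compound 4, 1.3-fold (0.12 log units) apart, within the scatter of two such steps. Going by these compounds alone, both steps are small enough to be indistinguishable from the ordinary variation between repeated measurements, so the series shows only that this one swap leaves the number essentially in place on these two cores; it does not show that the swap would behave the same way on a third core, in another assay, or that any other change would carry over between these cores.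

The compounds shown leave open whether a different group in this place, such as an amine, a carboxylic acid or a longer chain, would move the number beyond the scatter. No pair shown changes the core alone, so what the core itself contributes also remains open.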